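Replacing diisopropylamino in compound 2 with a triazole

The source may hold more compounds than are shown below. What is called first, only, known or untested is meant among the compounds shown, and "the series" means these compounds.

Compound 1 `CO[C@]1(C)/C=C/C(=O)/C(CO)=C\C[C@](C)(CCC=C(C)C)/C=C/[C@H]1OC(=O)C=C(C)C` gives 14400 nM
Compound 2 `CC(C)=CCC[C@]1(C)/C=C/[C@@H](OC(=O)C=C(C)C)[C@](C)(O)/C=C/C(=O)/C(CN(C(C)C)C(C)C)=C\C1` gives 650 nM

In a functional assay on A549 cells (Homo sapiens) for antiproliferative activity, read by MTT assay, with a stated time of 48 h (on this read-out higher numbers stand for weaker inhibition and lower numbers for stronger inhibition), compound 2 holds the lower of the two numbers, and its gap to compound 1 lies beyond the scatter. Compound 3 `CC(C)=CCC[C@]1(C)/C=C/[C@@H](OC(=O)C=C(C)C)[C@](C)(O)/C=C/C(=O)/C(Cn2cc(CO)nn2)=C\C1` carries 4-(hydroxymethyl)-1H-1,2,3-triazol-1-yl in place of diisopropylamino on a saturated chain carbon bound to a double-bonded ring carbon. For the measured compounds named here, no measured pair shows this swap, so the expectation is uncertain. The departing group belongs to compound 2 with 650 nM as the lower number. A weaker result beyond the scatter is therefore expected, an estimated step (a 4.6-fold higher number from compound 2 to compound 3 (0.66 log units; beyond the scatter)) upward. For compound 3 the expected value is 3000 nM (estimated range 800 nM to 12000 nM).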

Compound 3, half-maximal inhibitory concentration: 3470 nM
Compound 3: the middle estimate sits 1.2-fold (0.06 log units) below what was measured; the range from low to high includes it.
By their numbers in this assay, from the lowest: compound 2; then compound 3; then compound 1.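

In this assay the position on a saturated chain carbon bound to a double-bonded ring carbon proves sensitive: 4-(hydroxymethyl)-1H-1,2,3-triazol-1-yl in place of diisopropylamino gives a 5.3-fold higher number from compound 2 to compound 3 (0.73 log units; beyond the scatter) even though both groups have the same number of heavy atoms. Activity is weakened by this swap but still measurable as a number. Nothing measured here explains the change.

The compounds shown leave open whether the step follows the departure of the amine or the arrival of the triazole with its hydroxymethyl. A piperidine at this place, or a triazole carrying a plain methyl group, would help separate the two.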